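Replacing a nitrophenyl amide with a methoxyphenyl amide

The source may hold more compounds than are shown below. What is called first, only, known or untested is meant among the compounds shown, and "the series" means these compounds.

Measured so far:
compound 1, `CNC(=O)CSc1nc2ccc(NC(=O)c3ccccc3OC)cc2s1`, 18500 nM
compound 2, `CC(=O)Nc1ccc2nc(SCC(=O)NCc3ccc(Cl)cc3)sc2c1`, 6700 nM
compound 3, `O=C(CSc1nc2ccc(NC(=O)c3ccc([N+](=O)[O-])cc3)cc2s1)NCc1ccc(Cl)cc1`, > 100000 nM

In a functional assay on HepG2 cells (Homo sapiens) for cytotoxicity, read by MTT assay, with a stated time of 48 h (on this read-out lower numbers stand for stronger inhibition and higher numbers for weaker inhibition), compound 1 gives 18500 nM. In the same assay compound 2 gives 6700 nM. Compound 3 reaches only the limit of the limit of > 100000 nM in this assay, at which 1 of the 3 values shown sits, so its value is a limit of the assay and not a number. The one step among these compounds, an at least 14-fold higher number from compound 2 to compound 3 (1.17 log units; beyond the scatter), is therefore a large step and known only as a bound.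

The new compound 4, `COc1ccccc1C(=O)Nc1ccc2nc(SCC(=O)NCc3ccc(Cl)cc3)sc2c1`, differs from compound 3 in one place: 2-methoxyphenyl in place of 4-nitrophenyl on a carbonyl carbon. Going by the values given here, no measured step covers this exchange directly. The step from compound 2 to compound 3 shows that the 4-nitrophenyl carbonyl carries a high number, so removing it should, if anything, bring the number down. Compound 1 carries the same 2-methoxyphenyl carbonyl as compound 4, though with a different amide, and compound 1 gives 18500 nM.

From these points compound 4 is expected to show an at least 4.0-fold lower number from compound 3 to compound 4 (0.60 log units; beyond the scatter), a step in the direction of a lower number. The estimate for compound 4 is 25000 nM, with a range from 8000 nM to 100000 nM.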

Compound 4, half-maximal inhibitory concentration: 600 nM
For compound 4 the middle estimate is 42-fold (1.62 log units) above the measured one, outside the stated range (below it).
By their numbers in this assay, from the lowest: compound 4; then compound 2; then compound 1. At a limit, above all of these: compound 3.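

Compound 3 holds a limit of the assay and not a number: the limit of > 100000 nM in this assay, at which 1 of the 4 values shown sits.

In this assay, the exchange of 4-nitrophenyl for 2-methoxyphenyl on the carbonyl carbon gives an at least 160-fold lower number from compound 3 to compound 4 (2.22 log units; beyond the scatter), and the exchange of methyl for 2-methoxyphenyl gives an 11-fold lower number from compound 2 to compound 4 (1.05 log units; beyond the scatter), so a substituted phenyl at this place can lie on either side of methyl, which the earlier step alone did not show. The 2-methoxyphenyl carbonyl does not bring the low number by itself, since 4-chlorophenyl in place of hydrogen on the saturated chain carbon bound to the amide-type nitrogen gives a 31-fold lower number from compound 1 to compound 4 (1.49 log units; beyond the scatter), and compound 4 thus reads lower than both compound 1 and compound 2, each of which lacks one of its two end groups.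

The compounds shown leave open whether the methoxy group itself matters at the carbonyl, as they offer no comparison with a plain phenyl or with a phenyl carrying an amine or a carboxylic acid. Also open, going by these compounds, is how a longer chain carrying the 4-chlorophenyl would read in this assay.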